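Changing the Ring on a Piperazine Nitrogen

A few compounds are considered here, and "the series" means these few. Any claim that something is new, unique, unknown or untested is made for them only; others in the source may bear on it.

Within the data shown here, in a functional assay on the whole organism (strain Wistar) with Rattus norvegicus as the target, with a stated time of 5 min (on this read-out higher numbers stand for an effect only at larger amounts of compound and lower numbers for an effect already at smaller amounts), compound 2 `CCC1(CCCCN2CCN(c3ccc(Cl)cc3)CC2)C(=O)Nc2ccccc21` gives 10 mg/kg, the only number among the two compounds measured. Compound 1 `CCC1(CCCCN2CCN(c3ccc(C)c(Cl)c3)CC2)C(=O)Nc2ccccc21` gives > 20 mg/kg, which is a limit of the assay rather than a number, namely (the limit of > 20 mg/kg in this assay, at which 1 of the 2 values shown sits). The step of an at least 2.0-fold lower number from compound 1 to compound 2 (0.30 log units; that floor lies within the scatter) came with 4-chlorophenyl in place of 3-chloro-4-methylphenyl on an amine nitrogen in a ring. Compound 3 `CCC1(CCCCN2CCN(c3ccccc3OC)CC2)C(=O)Nc2ccccc21` differs from compound 2 by 2-methoxyphenyl in place of 4-chlorophenyl on an amine nitrogen in a ring. Among the measured compounds shown here, the single measured step changed the group on the same amine nitrogen in a ring, but it concerned chlorine and methyl groups rather than a methoxy group, and its size is known only as a floor. It therefore gives no firm direction for this assay. Compound 3 is expected to give about 10 mg/kg, within a range from 3 mg/kg to 30 mg/kg. That estimate means a step of no change at the digits printed from compound 2 to compound 3 (within the scatter), no change beyond the scatter.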

Compound 3, minimum effective dose: 10 mg/kg
The estimate for compound 3 equals the measured number at the digits printed, within the range that was stated.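

In this assay the move to 2-methoxyphenyl on this amine nitrogen in a ring gives no change at the digits printed from compound 2 to compound 3 (within the scatter) and so shows that a ring with a hydrogen-bond acceptor, which 4-chlorophenyl lacks, reads the same here as a ring with chlorine. Set against 3-chloro-4-methylphenyl, the same group gives an at least 2.0-fold lower number from compound 1 to compound 3 (0.30 log units; that floor lies within the scatter) and matches the earlier step, whose size is again known only as a floor. Compound 1 stands at a limit of the assay, not at a number: the limit of > 20 mg/kg in this assay, at which 1 of the 3 values shown sits.

From the compounds shown here alone, the swap from compound 2 to compound 3 changes both the group on the ring and where it sits, so it remains open how 2-chlorophenyl or 4-methoxyphenyl would read. Every compound shown keeps a carbon-only aromatic ring on this nitrogen, which leaves a pyridine ring or a plain benzyl group open too.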